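This account rests on a few compounds, and the source may have more. Where it says the series, first, only, none or still open, it means among the compounds named here.

In a functional assay on K562 cells (Homo sapiens), read by MTT assay, with a stated time of 72 h (a higher number here means a weaker inhibitor, a lower number a stronger inhibitor), compound 1 `CSc1ncnc2c1c(-c1cccs1)cn2[C@@H]1O[C@H](CO)[C@@H](O)[C@H]1O` gives > 20000 nM, which is a limit of the assay and not a number. Compound 2 `Cc1ncnc2c1c(-c1ccoc1)cn2[C@@H]1O[C@H](CO)[C@@H](O)[C@H]1O` gives > 20000 nM, which is also a limit. Compound 2 therefore stands at the limit of > 20000 nM in this assay, at which 2 of the 2 values shown sit, so no measured number shows how strongly it inhibits. The next structure, compound 3 `Cc1ncnc2c1c(-c1cccs1)cn2[C@@H]1O[C@H](CO)[C@@H](O)[C@H]1O`, has thiophen-2-yl in place of furan-3-yl on an aromatic carbon of the five-membered ring: thiophen-2-yl in place of furan-3-yl on an aromatic carbon. For the measured compounds named here, no measured step between two compounds is available to size this change, so any forecast is tentative. A shift towards stronger inhibition in this assay is expected, but compound 3 could also remain at the limit. The estimated change is an at least 5.0-fold lower number from compound 2 to compound 3 (0.69 log units; beyond the scatter). For compound 3, the expected value is 4000 nM, with an estimated range from 300 nM to 20000 nM.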

Compound 3, half-maximal inhibitory concentration: > 20000 nM
Compound 3: no number, only a limit; the forecaster's own chance of this, stated with the estimate: 40%; middle value at least 5.0-fold (0.69 log units) from the limit.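

Compound 3 also gives only a limit and not a number, so its steps from compound 1 and from compound 2 cannot be read: the limit of > 20000 nM in this assay, at which 3 of the 3 values shown sit. The compounds shown leave open how strongly each inhibits in this assay, and whether swapping thiophen-2-yl for furan-3-yl or methyl for methylsulfanyl changes that.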